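Swapping Oxime Ether Substituents on a Shared Core

The compounds below may be only part of what the source reports. "The series", "measured", "known", "first", "only" and "open" are said of these compounds alone.

Compound 1, `c1ccc(-c2cnccn2)c(NCC2=NCCN2)c1`: 182 nM
Compound 2, `CCO/N=C(\C)c1ccccc1NCC1=NCCN1`: < 5020 nM

In a functional assay for activation of Alpha-1D adrenergic receptor (Homo sapiens) (on this read-out higher numbers stand for an effect only at larger amounts of compound and lower numbers for an effect already at smaller amounts), compound 1 gives 182 nM. For compound 2 the assay reports only a limit, < 5020 nM, as noted in the limit of < 5020 nM in this assay, at which 1 of the 2 values shown sits. The step that the limit leaves unreadable from compound 1 to compound 2 is therefore unreadable. Compound 3, `CC/C(=N\OC)c1ccccc1NCC1=NCCN1`, differs from compound 2 by a group of 6 heavy atoms (4 carbon, 1 nitrogen, 1 oxygen; no ring) in place of a group of 6 heavy atoms (4 carbon, 1 nitrogen, 1 oxygen; no ring), on an aromatic carbon. Among the measured compounds shown here, no measured step covers such a rearrangement of the same atoms, so no direction beyond the scatter is expected. The step that the limit leaves unreadable from compound 2 to compound 3 is an estimate only. Compound 3 is expected near 2500 nM, within 400 nM to 10000 nM.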

Compound 3, half-maximal effective concentration: < 100000 nM
Compound 3: only a limit was reported; the forecaster's own chance of this, stated with the estimate: 50%; the middle value lies beyond the limit too.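

Compound 3 is reported only as a limit, so its steps from compound 1 and compound 2 cannot be read. As far as these compounds go, whether compound 3 acts at smaller or larger amounts than compound 2 stays open in this assay.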